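The compounds below may be only part of what the source reports. "The series", "measured", "known", "first", "only" and "open" are said of these compounds alone.

Compound 1 `COc1cc(-c2nn(-c3cccc(NC(=O)Nc4ccc(Cl)c(Cl)c4)c3)cc2-c2ccncc2)ccc1Cl` gives 1930 nM in a functional assay on SK-OV-3 cells (Homo sapiens) for inhibition, read by sulforhodamine B assay, with a stated time of 48 h; a lower number here means a stronger inhibitor of growth, a higher number a weaker inhibitor of growth.
Compound 2 `O=C(Nc1cccc(-n2cc(-c3ccncc3)c(-c3ccc(Cl)c(O)c3)n2)c1)Nc1ccc(Cl)c(Cl)c1` gives 1200 nM in this assay.
Compound 3 `COc1cc(-c2nn(-c3cccc(NC(=O)c4ccc(Cl)c(C(F)(F)F)c4)c3)cc2-c2ccncc2)ccc1Cl` gives 9290 nM in this assay.

Compound 2 and compound 1 sit close together at the low end of these three numbers: the step of a 1.6-fold lower number from compound 1 to compound 2 (0.21 log units; within the scatter) stays within the usual scatter, so the two cannot be told apart, while compound 3 lies clearly further up and is the weaker growth inhibitor. Compound 4 `O=C(Nc1cccc(-n2cc(-c3ccncc3)c(-c3ccc(Cl)c(O)c3)n2)c1)Nc1ccc(Cl)c(C(F)(F)F)c1` has not yet been measured. It differs from compound 2 in one place: trifluoromethyl in place of chloro on an aromatic carbon. Within the data shown here, no measured step isolates this swap on its own. The nearest guide is a 4.8-fold higher number from compound 1 to compound 3 (0.68 log units; beyond the scatter), but that step replaces (3,4-dichlorophenyl)amino with 4-chloro-3-(trifluoromethyl)phenyl on the carbonyl carbon, bundling the chloro-to-trifluoromethyl swap with a second change, so its size cannot be credited to the swap alone. Among the measured compounds shown here, with no clean precedent, the expected step for compound 4 in this assay is a 1.1-fold higher number from compound 2 to compound 4 (0.03 log units; within the scatter), most likely nothing beyond the scatter. Compound 4 is therefore estimated at 1300 nM, with a range from 500 nM to 3500 nM.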

Compound 4, concentration for 50% growth inhibition: 1340 nM
For compound 4 the middle estimate is 1.0-fold (0.01 log units) below the measured one, and the stated range covers the measured number.
By their numbers in this assay, from the lowest: compounds 2, 4 and 1 (each within the scatter of the next); then compound 3.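

Compound 4 isolates the swap of chloro (1 heavy atom) for trifluoromethyl (4 heavy atoms) on this aromatic carbon, ortho to a chloro group. In this assay, the swap gives a 1.1-fold higher number from compound 2 to compound 4 (0.05 log units; within the scatter) and so leaves growth inhibition indistinguishable, which means that the larger group is accepted here with no measurable loss. The clear rise in a 4.8-fold higher number from compound 1 to compound 3 (0.68 log units; beyond the scatter) therefore finds no match in this swap alone, although the two steps start from compounds that differ at another site, and no measured property of these groups is available to explain the flat result.

Going by these compounds, whether a nitrile, a methyl or an amine on this same carbon would also leave the number unchanged remains open. On these data alone, it is also open whether the swap stays this flat when the hydroxyl of compound 2 is replaced by the methoxy of compound 1.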